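The compounds below may be only part of what the source reports. "The series", "measured", "known", "first", "only" and "open" are said of these compounds alone.

Measured compounds in an assay on isolated protein for inhibition of Amine oxidase [flavin-containing] B (Homo sapiens), read by fluorescence and Amplex Red, with stated times of 15 min and 20 min; on this read-out higher numbers stand for weaker inhibition and lower numbers for stronger inhibition:
- compound 1, `C#CCN(C)CCCCOc1ccc2ccc(=O)oc2c1`: 27 nM
- compound 2, `C#CCN(CCCCOc1ccc2ccc(=O)oc2c1)Cc1ccc(OC)cc1`: 1130 nM
- compound 3, `C#CCN(CCCOc1ccc2ccc(=O)oc2c1)Cc1cccc(F)c1`: 4440 nM

Compound 1 stands lowest of the three numbers in this assay. For the measured compounds named here, the nearest is compound 2, and the one step recorded between single-point changes runs from compound 1 to compound 2: a 42-fold higher number from compound 1 to compound 2 (1.62 log units; beyond the scatter). Going by the values given here, compound 3 gives a higher number than compound 1 in this assay, beyond the scatter, but it differs from compound 1 in more than one place, so no single step is drawn to it.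

The next compound, compound 4, `C#CCN(CCCCOc1ccc2ccc(=O)oc2c1)Cc1ccccc1`, is not yet measured. Its difference from compound 1 is phenyl in place of hydrogen on a saturated chain carbon bound to an amine nitrogen. Among the compounds with values here, this is the same kind of change, at the same place, as the one from compound 1 to compound 2, where a 4-methoxyphenyl entered on a saturated chain carbon bound to an amine nitrogen and the number rose by a large step. Within the data shown here, the only step that bears on the present change is that one, and it points upward and well beyond the scatter.

A large step upward in this assay is therefore expected for compound 4, of roughly the size seen with compound 2, with some allowance for the missing methoxy. Expected step: a 26-fold higher number from compound 1 to compound 4 (1.41 log units; beyond the scatter). Compound 4 is estimated at 700 nM, within a range of 150 nM to 3000 nM.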

Compound 4, half-maximal inhibitory concentration: 978 nM
Estimate against measurement, compound 4: 1.4-fold (0.15 log units) below; low and high end bracket the measured number.
By their numbers in this assay, from the lowest: compound 1; then compounds 4 and 2 (each within the scatter of the next); then compound 3.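

In this assay, phenyl in place of hydrogen on a saturated chain carbon bound to an amine nitrogen is enough on its own for a large rise, with a 36-fold higher number from compound 1 to compound 4 (1.56 log units; beyond the scatter) as the reading. The methoxy on the aromatic carbon accounts for no readable part of the rise seen earlier, with a 1.2-fold lower number from compound 2 to compound 4 (0.06 log units; within the scatter) as the reading, so at this position the change is carried by the ring itself and not by that substituent. No measurement on hand bears on why this change raises the number.

Open, as far as these compounds go, is whether a smaller group at the same place, such as ethyl or cyclopropyl, keeps the number close to that of compound 1 or already gives a large rise. Also open, from the compounds shown here alone, is whether a pyridine ring in place of phenyl, or an amine or a carboxylic acid on the ring, would move the number, since methoxy is the only ring substituent compared on the chain of compound 4.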